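Compound 3: methyl in place of hydroxy

The source may report more compounds than this note shows. Statements on the series, on what has been measured and on what is new or still open speak of the compounds shown alone.

In a functional assay on MCF7 cells (Homo sapiens) for antiproliferative activity, read by MTT assay, with a stated time of 72 h (on this read-out lower numbers stand for stronger inhibition and higher numbers for weaker inhibition), compound 1 `O=S(=O)(Oc1cccc(C(F)(F)F)c1)C1CC2OC1C(c1ccc(/C=C/c3cc(O)cc(O)c3)cc1)=C2c1ccc(O)cc1` gives 11500 nM and compound 2 `O=S(=O)(Oc1ccc(O)cc1)C1CC2OC1C(c1ccc(/C=C/c3cc(O)cc(O)c3)cc1)=C2c1ccc(O)cc1` gives 14100 nM. Among the measured compounds shown here, these are the only two numbers so far, and compound 2 stands within the scatter of compound 1.

Compound 3 `Cc1ccc(OS(=O)(=O)C2CC3OC2C(c2ccc(/C=C/c4cc(O)cc(O)c4)cc2)=C3c2ccc(O)cc2)cc1` keeps the shared core and alters one group of compound 2: methyl in place of hydroxy on an aromatic carbon. In words, methyl takes the place of hydroxy on an aromatic carbon, para to a large group, so that 4-hydroxyphenyl becomes 4-methylphenyl.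

For the measured compounds named here, only one measured step bears on this change: a 1.2-fold higher number from compound 1 to compound 2 (0.09 log units; within the scatter). That step put 4-hydroxyphenyl in place of 3-(trifluoromethyl)phenyl on an oxygen, at the same site that changes here, and it stayed within the scatter. Going by the values given here, no measured pair tests methyl itself, so this evidence is thin. On this basis, no step beyond the scatter is expected in this assay, and no direction is favoured.

The estimate amounts to an expected step of a 1.1-fold lower number from compound 2 to compound 3 (0.05 log units; within the scatter). Compound 3 is estimated at 12500 nM, with an expected range of 6000 nM to 26000 nM.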

Compound 3, half-maximal inhibitory concentration: 9200 nM
Compound 3: middle estimate off by 1.4-fold (0.13 log units), on the high side, within the range that was stated.
By their numbers in this assay, from the lowest: compounds 3, 1 and 2 (each within the scatter of the next).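

Hydroxy and methyl are compared directly for the first time on this aromatic carbon, para to a large group: in this assay the change gives a 1.5-fold lower number from compound 2 to compound 3 (0.19 log units; within the scatter) and so does not separate the two groups, even though hydroxy is counted as a hydrogen-bond donor and acceptor and methyl as neither. Among the compounds shown here, the 4-methylphenyl group also cannot be told apart from 3-(trifluoromethyl)phenyl on the same oxygen, with a 1.3-fold lower number from compound 1 to compound 3 (0.10 log units; within the scatter) as the step, so none of the three steps among compounds 1, 2 and 3 leaves the scatter, and no compound in this set goes against that. No independent measurement is available to explain these small differences.

Still open, from the compounds shown here alone, is whether an amine, a carboxylic acid or a longer alkyl chain on this phenyl ring would produce a step beyond the scatter in this assay or would stay as close as the groups seen so far. Also open, going by these compounds, is whether a simple unsubstituted phenyl on the oxygen would fall within the same narrow band, which would show how little this substituent matters to the read-out.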